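The source may report more compounds than this note shows. Statements on the series, on what has been measured and on what is new or still open speak of the compounds shown alone.

Measured compounds:
- Compound 1, `CCN(CC)S(=O)(=O)c1ccc(S(=O)(=O)N2CCC[C@@H](C(=O)N3CCC(c4nc(C(C)C)no4)CC3)C2)cc1`, gives 40 nM
- Compound 2, `CCOC(=O)[C@@H]1C[C@@H](O)CN(S(=O)(=O)c2ccc(S(=O)(=O)N(CC)CC)cc2)C1`, gives 7900 nM

Both compounds were tested in a functional assay on MIA PaCa-2 cells (Homo sapiens) for inhibition, read by MTT assay, with a stated time of 7 days; on this read-out lower numbers stand for stronger inhibition and higher numbers for weaker inhibition. Compound 1 stands at the low end of the two numbers with 40 nM; compound 2, with 7900 nM, sits far above it, a gap well beyond the usual scatter. Compound 2 shares the diethylsulfamoyl-bearing part of the structure with compound 1 but differs in several other places, so these two values by themselves say nothing about any single change.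

Compound 3, `CC(C)c1noc(C2CCN(C(=O)[C@@H]3CCCN(S(=O)(=O)c4ccc(S(=O)(=O)C(C)C)cc4)C3)CC2)n1`, is not yet measured. It differs from compound 1 in one place: isopropyl in place of diethylamino on a sulfonyl sulfur. The rest of the molecule is unchanged. Among the compounds with values here, no measured pair shows this change, so its effect is unknown; a step of modest size is expected, more likely toward a weaker result than a stronger one, as a 2.0-fold higher number from compound 1 to compound 3 (0.30 log units; within the scatter). Compound 3 is therefore estimated at 80 nM, with a range from 20 nM to 400 nM.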

Compound 3, half-maximal inhibitory concentration: 50 nM
The estimate for compound 3 lay 1.6-fold (0.20 log units) above the measured number, within the range that was stated.
By their numbers in this assay, from the lowest: compounds 1 and 3 (each within the scatter of the next); then compound 2.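

In this assay, isopropyl in place of diethylamino on a sulfonyl sulfur gives a 1.3-fold higher number from compound 1 to compound 3 (0.10 log units; within the scatter), so this change leaves the read-out indistinguishable. The group that leaves has 5 heavy atoms, one of them nitrogen, while the group that enters has 3, all carbon, so at this position neither that nitrogen nor the two extra heavy atoms are needed for a value in this range. Nothing available explains why the swap makes so little difference.

Both groups are free of rings, and neither carries a hydrogen-bond donor or acceptor, so the result says little about how a carboxylic acid, a primary amine or a phenyl ring would fare on that sulfonyl sulfur. From the compounds shown here alone, whether the same swap would leave the value in place on a different core also remains open.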